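Replacing a Terminal Hydroxy with Ethyl on the Ether Chain

The compounds below may be only part of what the source reports. "The series", "measured", "known", "first", "only" and "open" are said of these compounds alone.

Compound 2 `CC(C)NC(=O)N(CCCCCSc1nc(-c2ccccc2)c(-c2ccccc2)[nH]1)CCOCCO` gives 90 nM in an assay on microsomes from liver with sterol O-acyltransferase 1 (Rattus norvegicus) as the target (on this read-out higher numbers stand for weaker inhibition and lower numbers for stronger inhibition), the lowest of the two numbers measured. Compound 1 `CCN(CC)CCN(CCCCCSc1nc(-c2ccccc2)c(-c2ccccc2)[nH]1)C(=O)NC(C)C` gives 660 nM. Within the data shown here, the only measured step, a 7.3-fold lower number from compound 1 to compound 2 (0.87 log units; beyond the scatter), changed a different part of the chain and offers just a loose guide. Compound 3 `CCCCOCCN(CCCCCSc1nc(-c2ccccc2)c(-c2ccccc2)[nH]1)C(=O)NC(C)C` differs from compound 2 by ethyl in place of hydroxy on a saturated chain carbon, two bonds along the chain from an oxygen on a saturated carbon. Among the measured compounds shown here, with no measured step on this exact change, a shift of at most modest size is expected, in either direction, as a 1.7-fold higher number from compound 2 to compound 3 (0.22 log units; within the scatter). Compound 3 is therefore estimated at 150 nM, within 40 nM to 550 nM.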

Compound 3, half-maximal inhibitory concentration: 190 nM
The estimate for compound 3 lay 1.3-fold (0.10 log units) below the measured number; the range from low to high includes it.
By their numbers in this assay, from the lowest: compound 2; then compound 3; then compound 1.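

Exchanging the terminal hydroxy for ethyl, which turns 2-hydroxyethoxy into butoxy, gave a 2.1-fold higher number from compound 2 to compound 3 (0.32 log units; beyond the scatter) in this assay and so showed that the hydroxy is not needed for a number well under that of compound 1, though the hydroxy-ended chain remains lower. Butoxy in place of diethylamino gave a 3.5-fold lower number from compound 1 to compound 3 (0.54 log units; beyond the scatter) and, with compound 2, puts both ether chains below the diethylamino chain. No supporting evidence bears on why these numbers differ. Still open, going by these compounds, is how a carboxylic acid, a primary amine or a longer ether chain would compare at this chain end.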